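Replacing 3-chloro-4-fluorophenyl with 3-(2-aminoethoxy)phenyl: solubility notes

This account rests on a few compounds, and the source may have more. Where it says the series, first, only, none or still open, it means among the compounds named here.

Two measured compounds anchor this part of the series in a physicochemical assay for solubility, read by HPLC, using the shake flask method, in phosphate buffer, with a stated time of 20 h, at pH 6.5; on this read-out lower numbers stand for lower solubility and higher numbers for higher solubility. Compound 1 `Fc1ccc(-c2nc3c(N4CCN5CCCC5C4)nccc3[nH]2)cc1F` gives 120000 nM. Compound 2 `CN1CCN(CC2CCN(c3nccc4[nH]c(-c5ccc(F)c(Cl)c5)nc34)CC2)CC1` gives 155000 nM, a number within the usual scatter of the value for compound 1. Neither compound can therefore be placed ahead of the other on solubility.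

The next structure is compound 3 `CN1CCN(CC2CCN(c3nccc4[nH]c(-c5cccc(OCCN)c5)nc34)CC2)CC1`, which differs from compound 2 at a single place. On an aromatic carbon of a five-membered aromatic ring with 2 nitrogen, part of a fused or bridged system of two rings, between two ring nitrogen atoms, 3-(2-aminoethoxy)phenyl stands in place of 3-chloro-4-fluorophenyl: 3-(2-aminoethoxy)phenyl in place of 3-chloro-4-fluorophenyl on an aromatic carbon.

Among the measured compounds shown here, no measured step covers this change, which leaves the expectation poorly anchored. A small upward movement in this assay, not beyond the scatter, is expected. The expected size is a 1.4-fold higher number from compound 2 to compound 3 (0.15 log units; within the scatter). For compound 3 the estimated solubility is 220000 nM, with an expected range from 120000 nM to 450000 nM.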

Compound 3, solubility: 200000 nM
For compound 3 the middle estimate is 1.1-fold (0.04 log units) above the measured one; low and high end bracket the measured number.
By their numbers in this assay, from the lowest: compounds 1, 2 and 3 (each within the scatter of the next).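

Among the compounds shown here, this is the first single-place step: on an aromatic carbon of the five-membered aromatic ring, between two ring nitrogen atoms, 3-(2-aminoethoxy)phenyl in place of 3-chloro-4-fluorophenyl gives in this assay a 1.3-fold higher number from compound 2 to compound 3 (0.11 log units; within the scatter). The step lies within the scatter, so this read-out does not separate the two groups, even though the leaving group has 8 heavy atoms, 0 hydrogen-bond donors and 0 hydrogen-bond acceptors, and the entering group has 10 heavy atoms, 1 hydrogen-bond donor and 2 hydrogen-bond acceptors. No measurement shown here bears on the reason for this outcome.

One step at one place cannot show whether other groups on this aromatic carbon would also stay within the scatter, for example a carboxylic acid in place of the amine of the 2-aminoethoxy chain, or a longer chain carrying the same amine. As far as these compounds go, it also remains open whether the same exchange would give a step of similar size on the core of compound 1, which carries a different amine-containing ring system.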